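The source may hold more compounds than are shown below. What is called first, only, known or untested is meant among the compounds shown, and "the series" means these compounds.

Measured so far in a functional assay for inhibition of sodium/hydrogen exchanger (Oryctolagus cuniculus); a higher number here means a weaker inhibitor, a lower number a stronger inhibitor:
compound 1 `Cc1cc(SC(C)C)c(S(C)(=O)=O)cc1C(=O)N=C(N)N`: 12 nM
compound 2 `Cc1cc(Sc2cccc(Cl)c2)c(S(C)(=O)=O)cc1C(=O)N=C(N)N`: 37 nM

Among the measured compounds shown here, compound 2 holds the higher of the two numbers; its nearest neighbour is compound 1, and the only step in hand is a 3.1-fold higher number from compound 1 to compound 2 (0.49 log units; beyond the scatter), which puts compound 2 beyond the scatter on the weaker side.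

Compound 3 `Cc1cc(-n2ccnc2C)c(S(C)(=O)=O)cc1C(=O)N=C(N)N` differs from compound 2 in one place: 2-methyl-1H-imidazol-1-yl in place of (3-chlorophenyl)sulfanyl on an aromatic carbon. For the measured compounds named here, no measured step describes this kind of exchange. Going by the values given here, the single known step concerns the group on the sulfur, not the loss of the sulfur-linked ring itself, so it bears on the new change only loosely. With the larger sulfur-bound ring gone and a smaller ring attached directly, the number for compound 3 is expected to fall back toward that of compound 1, but the range must stay wide. For compound 3 the expected step is a 1.5-fold lower number from compound 2 to compound 3 (0.17 log units; within the scatter). The estimate for compound 3 in this assay is 25 nM, ranging from 6 nM to 100 nM.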

Compound 3, half-maximal inhibitory concentration: 29 nM
Compound 3: middle estimate off by 1.2-fold (0.06 log units), on the low side; low and high end bracket the measured number.
By their numbers in this assay, from the lowest: compound 1; then compounds 3 and 2 (each within the scatter of the next).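

In this assay, the sulfur link is not required at this position, ortho to a methylsulfonyl group: replacing (3-chlorophenyl)sulfanyl with 2-methyl-1H-imidazol-1-yl gives a 1.3-fold lower number from compound 2 to compound 3 (0.11 log units; within the scatter) and leaves the reading within the scatter. Replacing isopropylsulfanyl with the same ring gives a 2.4-fold higher number from compound 1 to compound 3 (0.38 log units; beyond the scatter) and stays beyond the scatter, so neither ring-bearing group in hand reaches the number of compound 1. No measured property in hand bears on these results.

An amine such as dimethylamino or a methoxy group, with neither ring nor sulfur, could show whether this position sides with compound 1 or with compounds 2 and 3. The part played by the methyl on the imidazole also stays open, as unsubstituted 1H-imidazol-1-yl is not among the compounds shown.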